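Carbamate in place of benzyl ether on the shared core

The compounds below may be only part of what the source reports. "The series", "measured", "known", "first", "only" and "open" are said of these compounds alone.

Within the data shown here, compound 1 `CC(C)=CCC1Cc2c(OCc3ccccc3)cc(=O)n(CCCO)c2CC1(C)C` stands lowest of the two numbers so far in a functional assay on PANC-1 cells (Homo sapiens) for inhibition, read by MTT assay, with a stated time of 24 h, tested at 10 uM; a higher number here means more inhibition at the concentration tested (going by the name of the read-out), a lower number less inhibition: compound 1 gives -0.3%, while compound 2 `CC(C)=CCC1Cc2c(OCCCNS(=O)(=O)c3ccc(C(F)(F)F)cc3)cc(=O)n(CCCO)c2CC1(C)C` gives 29.6%, a gap beyond the usual scatter. Compound 3 `CC(C)=CCC1Cc2c(OC(=O)Nc3ccc(F)c(F)c3)cc(=O)n(CCCO)c2CC1(C)C` differs from compound 1 by (3,4-difluorophenyl)carbamoyl in place of benzyl on an oxygen on an aromatic ring. Among the measured compounds shown here, no measured pair shows this exact change, so its size is uncertain. For the measured compounds named here, the one change of this substituent seen so far, compound 2 against compound 1, went upward, and a rise beyond the scatter is expected here as well, with the expected step being a number 15.3 percentage points higher from compound 1 to compound 3 (beyond the scatter). For compound 3 the estimate is 15%, within 0% to 35%.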

Compound 3, a percentage reported as inhibition, at one concentration (the size of the read-out at that concentration, not a potency): 76.7%
For compound 3 the middle estimate is 61.7 percentage points below the measured one, outside the stated range (above it).
By their numbers in this assay, from the lowest: compound 1; then compound 2; then compound 3.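

At the oxygen on the aromatic ring, (3,4-difluorophenyl)carbamoyl in place of benzyl gives a number 77 percentage points higher from compound 1 to compound 3 (beyond the scatter) in this assay, so this position on the shared core can carry a large rise. The step brings in the carbamoyl and the fluorine atoms together, and this single pair does not separate them. Nothing at hand accounts for the size of the step.

Open, going by these compounds, is whether the rise follows the carbamoyl or the fluorine atoms. An unsubstituted phenylcarbamoyl on the same oxygen would bear on that question.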